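This account rests on a few compounds, and the source may have more. Where it says the series, first, only, none or still open, it means among the compounds named here.

Working notes on the series, cytotoxicity.

Compound 3 `COc1ccc2nc(C)cc(OCC(=O)Nc3ccc(Cl)c(OC)c3)c2c1` is the reference point. In a toxicity assay on HepG2 cells (Homo sapiens) for inhibition, read by CellTiter-Glo, with a stated time of 48 h (on this read-out higher numbers stand for weaker inhibition and lower numbers for stronger inhibition), compound 3 gives > 100000 nM, which is a limit of the assay and not a number. Compound 1 `COc1ccc2nc(C)cc(OCC(=O)Nc3cc(C)ccc3C)c2c1` carries a 2,5-dimethylphenyl on the amide nitrogen; in this assay compound 1 gives > 100000 nM, again a limit rather than a number. Compound 2 `COc1ccc2nc(C)cc(OCC(=O)Nc3cc(C)ccc3OC)c2c1` has a methoxy in place of one methyl; in this assay compound 2 gives > 100000 nM, also a limit. The steps among them are therefore unreadable: a step that the two limits leave unreadable from compound 1 to compound 2, a step that the two limits leave unreadable from compound 1 to compound 3 and a step that the two limits leave unreadable from compound 2 to compound 3. What the set does show is the limit of > 100000 nM in this assay, at which 3 of the 3 values shown sit.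

Compound 4 `COc1ccc2nc(C)cc(OCC(=O)Nc3ccc(F)cc3)c2c1` is the next member. The change from compound 3 is 4-fluorophenyl in place of 4-chloro-3-methoxyphenyl on an amide-type nitrogen. Going by the values given here, no measured step bears on this change in a readable way; the only evidence is that every aryl amide so far sits at the limit, as in the limit of > 100000 nM in this assay, at which 3 of the 3 values shown sit. On that basis no movement beyond the scatter is expected, and compound 4 is expected to sit at the limit as well, with a step of a number no higher from compound 3 to compound 4 (the limit leaves the size open). The estimate for compound 4 in this assay is 100000 nM, within 40000 nM to 300000 nM, most likely reported only as a limit.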

Compound 4, half-maximal inhibitory concentration: 63100 nM
Compound 4: the middle estimate sits 1.6-fold (0.20 log units) above what was measured; the range from low to high includes it.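

On an amide-type nitrogen, 4-fluorophenyl gives compound 4 a number rather than a limit in this assay, which shows that a change at this position alone can bring a reading within the range of the assay, while compound 1, compound 2 and compound 3 each remain at a limit: the limit of > 100000 nM in this assay, at which 3 of the 4 values shown sit.

Set against those limits, the change can be given only as a floor on one side: an at least 1.5-fold lower number from compound 3 to compound 4 (0.19 log units; that floor lies within the scatter), an at least 1.5-fold lower number from compound 2 to compound 4 (0.19 log units; that floor lies within the scatter) and an at least 1.5-fold lower number from compound 1 to compound 4 (0.19 log units; that floor lies within the scatter); the true size of each of these steps stays open. The 4-fluorophenyl group differs from each of the three groups it replaces in more than one place on the ring, so this result ties the reading to the whole aryl group and not to the fluorine alone.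

Still open, on these data alone, is how an unsubstituted phenyl or a 4-chlorophenyl on the same nitrogen would read in this assay, which would separate the fluorine from the loss of the methoxy and methyl groups. Also open, as far as these compounds go, is whether a saturated ring such as cyclohexyl, or an aryl group carrying an amine or a carboxylic acid, would give a number at all.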